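From 4-chlorobenzyl to 4-(trifluoromethyl)benzyl

This account rests on a few compounds, and the source may have more. Where it says the series, first, only, none or still open, it means among the compounds named here.

Measured so far in a functional assay on RAW264.7 cells (Mus musculus) for inhibition, read by polymerase chain reaction, with stated times of 12 h and 6 h; on this read-out lower numbers stand for stronger inhibition and higher numbers for weaker inhibition:
- compound 1 `COc1ccc(CN2CCC(NC(=O)C(C)(C)CCCOc3cc(C)ccc3C)CC2)cc1` gives 4150 nM
- compound 2 `Cc1ccc(C)c(OCCCC(C)(C)C(=O)NC2CCN(Cc3ccc(Cl)cc3)CC2)c1` gives 14800 nM

Of the two measured compounds, compound 2 has the higher number, 14800 nM and therefore the weaker inhibition.

Compound 3 `Cc1ccc(C)c(OCCCC(C)(C)C(=O)NC2CCN(Cc3ccc(C(F)(F)F)cc3)CC2)c1` has not yet been measured. Its difference from compound 2 is trifluoromethyl in place of chloro on an aromatic carbon and amounts to trifluoromethyl in place of chloro on an aromatic carbon.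

Going by the values given here, only one measured step bears on this change. Among the compounds with values here, it also replaces a group on an aromatic carbon, with chloro in place of methoxy: a 3.6-fold higher number from compound 1 to compound 2 (0.55 log units; beyond the scatter) and this modest step is the only guide. Within the data shown here, no measured compound yet carries trifluoromethyl, so the direction remains open. A step no larger than that one is expected in this assay and most likely none beyond the scatter. The estimate corresponds to a 1.1-fold higher number from compound 2 to compound 3 (0.03 log units; within the scatter) as the expected step. For compound 3 the estimated value is 16000 nM with an expected range from 6000 nM to 40000 nM in these notes.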

Compound 3, half-maximal inhibitory concentration: 5170 nM
Beside the measured number, compound 3's estimate is 3.1-fold (0.49 log units) above it, outside the stated range (below it).
By their numbers in this assay, from the lowest: compounds 1 and 3 (each within the scatter of the next); then compound 2.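

In this assay, going by these compounds alone, the aromatic carbon para to a large group now has a second measured change: trifluoromethyl in place of chloro gives a 2.9-fold lower number from compound 2 to compound 3 (0.46 log units; beyond the scatter), so the single earlier step is no longer the only sign that this position responds to substitution. Trifluoromethyl and methoxy are not separated here, with a 1.2-fold higher number from compound 1 to compound 3 (0.10 log units; within the scatter), and among the three groups shown only chloro stands apart, since compound 2 has steps beyond the scatter to both compound 1 and compound 3. Nothing measured here accounts for chloro standing apart from the other two groups.

On these data alone, whether a nitrile, a carboxylic acid or an amine on this aromatic carbon would read with chloro or with methoxy and trifluoromethyl remains open. As far as these compounds go, it is also open whether the gap between chloro and the other two groups would persist with a change elsewhere in the shared core, such as a longer chain, since all three compounds differ only in this one place.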